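The source may report more compounds than this note shows. Statements on the series, on what has been measured and on what is new or still open speak of the compounds shown alone.

Three compounds sharing one core were tested in a functional assay on PC-3M cells (Homo sapiens) for cytotoxicity, read by MTT assay, with a stated time of 48 h; on this read-out higher numbers stand for weaker inhibition and lower numbers for stronger inhibition. Compound 1 `C=CCSc1nnc(-c2cc(OC)c(OC)c(OC)c2)n1N1C(=O)c2ccccc2C1=O` reaches only a limit of the assay, > 200000 nM. Compound 2 `C#CCSc1nnc(-c2cc(OC)c(OC)c(OC)c2)n1N1C(=O)c2ccccc2C1=O` likewise gives only a limit, > 200000 nM. Going by the values given here, compound 3 `COc1cc(-c2nnc(SCC(=O)c3ccc(Cl)cc3)n2N2C(=O)c3ccccc3C2=O)cc(OC)c1OC` is the one compound with a true number, giving 20700 nM in this assay, so it stands alone as the only measured value among the three. The step that the two limits leave unreadable from compound 1 to compound 2 cannot be read because both ends sit at the limit of > 200000 nM in this assay, at which 2 of the 3 values shown sit. By contrast, the step of an at least 9.6-fold lower number from compound 1 to compound 3 (0.98 log units; beyond the scatter) and the step of an at least 9.6-fold lower number from compound 2 to compound 3 (0.98 log units; beyond the scatter) both point the same way: attaching the (4-chlorophenyl)carbonyl group brought a number into view.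

Compound 4 `COc1cc(-c2nnc(SC)n2N2C(=O)c3ccccc3C2=O)cc(OC)c1OC` differs from compound 3 by hydrogen in place of (4-chlorophenyl)carbonyl on a saturated chain carbon bound to a sulfur. This change removes exactly the group whose arrival marked the two readable steps, so the expectation is that the number climbs back toward the limit. The expected step is a 7.2-fold higher number from compound 3 to compound 4 (0.86 log units; beyond the scatter), a rise. Compound 4 is therefore estimated at 150000 nM, within a range from 40000 nM to 600000 nM.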

Compound 4, half-maximal inhibitory concentration: > 200000 nM
Compound 4 was reported as a limit (the forecaster's own chance of this, stated with the estimate: 50%); middle value at least 1.3-fold (0.12 log units) from the limit.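

Replacing the (4-chlorophenyl)carbonyl group with hydrogen, which leaves a plain methylsulfanyl, gives an at least 9.6-fold higher number from compound 3 to compound 4 (0.98 log units; beyond the scatter) in this assay, a step whose far end is a limit of the assay and not a number. Until now, that group had been compared only with vinyl and ethynyl; compound 4 shows that the shared core with a bare methylsulfanyl also yields no number, so among these four compounds only compound 3 gives one, and none goes against this. The steps from compound 1 and from compound 2 to compound 4 cannot be read because all three compounds sit at one limit: the limit of > 200000 nM in this assay, at which 3 of the 4 values shown sit.

Which part of the (4-chlorophenyl)carbonyl group matters remains open: the chlorine, the ring or the carbonyl. A plain benzoyl group or a 4-chlorobenzyl group, which lacks the carbonyl, would begin to separate them.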